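A few compounds are considered here, and "the series" means these few. Any claim that something is new, unique, unknown or untested is made for them only; others in the source may bear on it.

Measured so far:
compound 1, `CCOC(=O)c1c(-c2ccc(OC)c(OC)c2)csc1N(C)C`: 60%
compound 2, `COCC(C)OC(=O)c1c(-c2ccc(OC)c(OC)c2)csc1N`: 49%

The read-out throughout is an assay on isolated protein for inhibition of protein kinase C zeta type (Homo sapiens), with stated times of 1 h and 2.5 min, tested at 30 uM; a lower number here means less inhibition, a higher number more inhibition at the concentration tested (going by the name of the read-out). In this assay compound 1 gives 60%. In this assay compound 2 gives 49%. Within the data shown here, compound 2 thus stands at the lower of the two numbers; the only other number, that of compound 1, lies higher by a gap beyond the usual scatter. Compound 1 and compound 2 differ from each other in more than one place on the shared core, so that gap cannot be read as a single structural step and gives no direct guide to the change considered here.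

Compound 3, `COCCNC(=O)c1c(-c2ccc(OC)c(OC)c2)csc1N`, is not yet measured. It differs from compound 2 in one place: (2-methoxyethyl)amino in place of 1-(methoxymethyl)ethoxy on a carbonyl carbon. Among the measured compounds shown here, no pair of measured compounds shows the effect of such a swap on a carbonyl carbon, so its direction is unknown; what is known is only that compound 2 sits at 49%. The step from compound 2 is expected to be a number 4 percentage points lower from compound 2 to compound 3 (within the scatter), which is not beyond the scatter. Compound 3 is estimated at 45%, with a range from 20% to 70%.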

Compound 3, a percentage reported as inhibition, at one concentration (the size of the read-out at that concentration, not a potency): 55%
Compound 3: the middle estimate sits 10 percentage points below what was measured; measured number inside the range.
By their numbers in this assay, from the lowest: compounds 2, 3 and 1 (each within the scatter of the next, the first and the last beyond it).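

In this assay, among these compounds, placing (2-methoxyethyl)amino in place of 1-(methoxymethyl)ethoxy on a carbonyl carbon gives a number 6 percentage points higher from compound 2 to compound 3 (within the scatter), the only single-place step so far. For this one pair, the position accepts a change from 0 to 1 hydrogen-bond donors and from 2 to 1 hydrogen-bond acceptors, with 5 heavy atoms entering for 6 and the chain losing its branch, without a change in the read-out beyond the scatter. No measurement at hand bears on why the two groups read alike, and this one pair sets no trend for the position.

Compound 1 differs from compound 2 and from compound 3 in more than one place, so the separate contributions of its carbonyl substituent and of the other changed place on the shared core remain unresolved. Also open is whether a carboxylic acid, a longer chain or a cyclic amine on this carbonyl carbon would stay within the scatter of compound 2, and the single-concentration read-out in this assay gives no potency for any of these compounds.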